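The source may report more compounds than this note shows. Statements on the series, on what has been measured and on what is new or still open speak of the compounds shown alone.

Compound 1, `CCn1c([C@@H](C)NS(=O)(=O)c2ccc(Cl)cc2)nc2ccccc21`: in an ADME assay (liver) for metabolic stability, with Liver microsome (Homo sapiens) as the target, read by LC-MS, using microsomes and NADPH, with a stated time of 5 min, at 37 degrees C (a lower number here means slower removal, a higher number faster removal of the compound), compound 1 gives > 100 mL.min-1.g-1, which is a limit of the assay rather than a number.
Compound 2, `CCn1c([C@@H](C)NS(=O)(=O)c2c(F)cc(F)cc2F)nc2ccc(C(F)(F)F)cc21`: in this assay compound 2 gives 19 mL.min-1.g-1.

Going by the values given here, compound 2 therefore holds the only real number measured so far in this assay. Among the compounds with values here, the one other value belongs to compound 1 and sits at the limit of > 100 mL.min-1.g-1 in this assay, at which 1 of the 2 values shown sits.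

Compound 3, `CCn1c([C@@H](C)NS(=O)(=O)c2cnc(C)n2C)nc2ccc(C(F)(F)F)cc21`, has not yet been measured. It differs from compound 2 in a single place: 1,2-dimethyl-1H-imidazol-5-yl in place of 2,4,6-trifluorophenyl on a sulfonyl sulfur. Within the data shown here, no measured pair in this small set shares this change, so there is no measured step of this kind to lean on, and the expectation rests on compound 2 alone.

In this assay the step from compound 2 to compound 3 is expected to be small, staying within the usual scatter of repeat measurements or at most a modest lowering of the clearance. The estimate for compound 3 in this assay is 14 mL.min-1.g-1, with a range from 5 mL.min-1.g-1 to 40 mL.min-1.g-1. The expected step is a 1.4-fold lower number from compound 2 to compound 3 (0.13 log units; within the scatter).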

Compound 3, intrinsic clearance in microsomes: 58 mL.min-1.g-1
Compound 3: middle estimate off by 4.1-fold (0.62 log units), on the low side; measured number above the stated range.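

Putting 1,2-dimethyl-1H-imidazol-5-yl in place of 2,4,6-trifluorophenyl on a sulfonyl sulfur gives a 3.1-fold higher number from compound 2 to compound 3 (0.48 log units; beyond the scatter) in this assay. Going by these compounds alone, this is the first measured step in which only this one group changes, and it shows that the group on the sulfonyl sulfur can by itself shift the clearance, here towards faster removal, with the rest of the molecule held the same. Within the data shown here, nothing measured so far offers a reason for this rise.

The step changes several things at once, since a six-membered aromatic ring of carbon with three fluorine atoms leaves and a five-membered aromatic ring with 2 hetero atoms and two methyl groups enters, so the compounds shown cannot tell which of these differences matters. Also open, from the compounds shown here alone, are where a plain phenyl or a pyridine ring on the sulfonyl sulfur would fall in this assay, and whether the same exchange would move the number by a similar amount on a core without the trifluoromethyl group.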